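The compounds below may be only part of what the source reports. "The series", "measured", "known", "first", "only" and "open" are said of these compounds alone.

Compound 1, with the structure `NC(=O)CS[C@H]1O[C@H](CO)[C@@H](O)[C@H](O)[C@H]1O`, is the parent amide of this short series; in an assay on isolated protein (Sus scrofa) for inhibition of glycogen phosphorylase, brain form (Homo sapiens) (on this read-out higher numbers stand for weaker inhibition and lower numbers for stronger inhibition), compound 1 gives 20000000 nM. Compound 2, with the structure `O=C(CS[C@H]1O[C@H](CO)[C@@H](O)[C@H](O)[C@H]1O)Nc1ccccc1`, carries a phenyl on the amide-type nitrogen, and in this assay compound 2 gives 3980000 nM. Among the two measured numbers compound 2 holds the lowest one, and the only measured step, a 5.0-fold lower number from compound 1 to compound 2 (0.70 log units; beyond the scatter), separates it from compound 1 by more than the usual scatter.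

Compound 3, with the structure `O=C(CS[C@H]1O[C@H](CO)[C@@H](O)[C@H](O)[C@H]1O)Nc1ccc(F)cc1F`, differs from compound 2 by 2,4-difluorophenyl in place of phenyl on an amide-type nitrogen. Among the compounds with values here, no measured step involves a substituted phenyl, so the single step from compound 1 to compound 2 bears on the change only indirectly: it shows that the aryl group on the amide-type nitrogen matters, but says nothing about fluorine substitution on that group. A step smaller than the measured one, in either direction, seems most plausible, with a step that stays within the scatter fully possible. The estimate for compound 3 in this assay is 2500000 nM, with a range from 800000 nM to 8000000 nM. The step that this estimate means, a 1.6-fold lower number from compound 2 to compound 3 (0.20 log units; within the scatter), is expected to be small.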

Compound 3, inhibition constant: 20000000 nM
Estimate against measurement, compound 3: 8.0-fold (0.90 log units) below; measured number outside the range, above it.
By their numbers in this assay, from the lowest: compound 2; then compounds 1 and 3 (each within the scatter of the next).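

The fluorines undo what phenyl gave at this position: in this assay, the change to 2,4-difluorophenyl on the amide-type nitrogen brings a 5.0-fold higher number from compound 2 to compound 3 (0.70 log units; beyond the scatter), a step as large as the earlier 5.0-fold lower number from compound 1 to compound 2 (0.70 log units; beyond the scatter) but opposite in direction. Set against the parent amide, the same group gives no change at the digits printed from compound 1 to compound 3 (within the scatter), so the lower number of compound 2 belongs to phenyl in particular and not to any aryl group placed on that nitrogen, with compound 3 as the case that goes against such a general reading. Nothing among the available data explains why the added fluorines have this result.

The compounds shown leave open whether a single fluorine on the phenyl would behave like the pair in compound 3 or leave the number near that of compound 2. They also leave open where a chlorophenyl, a methoxyphenyl or a benzyl on the amide-type nitrogen would fall, and so whether compound 2 marks a narrow preference or one point in a broader range.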